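Replacing the aromatic amide group with an aminopropyl chain

This account rests on a few compounds, and the source may have more. Where it says the series, first, only, none or still open, it means among the compounds named here.

Compound 1 `O=C(CCC(=O)OCCCCCCSc1ccc([N+](=O)[O-])c2nonc12)Nc1ccccc1F`: 9890 nM
Compound 2 `O=C(CCC(=O)OCCCCCCSc1ccc([N+](=O)[O-])c2nonc12)Nc1ccccc1Cl`: 15500 nM
Compound 3 `COc1ccc(NC(=O)CCC(=O)OCCCCCCSc2ccc([N+](=O)[O-])c3nonc23)cc1OC`: 6470 nM

All three were tested in an assay on isolated protein for inhibition of glutathione S-transferase P (Homo sapiens), with a stated time of 10 min; on this read-out lower numbers stand for stronger inhibition and higher numbers for weaker inhibition. Compound 1 stands second highest of the three numbers; the nearest step is a 1.5-fold lower number from compound 1 to compound 3 (0.18 log units; within the scatter) and the furthest is a 1.6-fold higher number from compound 1 to compound 2 (0.20 log units; within the scatter), both within the scatter. Compound 4 `CN(C)CCCNC(=O)CCC(=O)OCCCCCCSc1ccc([N+](=O)[O-])c2nonc12` has not been measured. It differs from compound 1 in this way: 3-(dimethylamino)propyl in place of 2-fluorophenyl on an amide-type nitrogen. The steps that touch the same amide-type nitrogen, a 1.6-fold higher number from compound 1 to compound 2 (0.20 log units; within the scatter) and a 1.5-fold lower number from compound 1 to compound 3 (0.18 log units; within the scatter), were within the scatter, and a 2.4-fold lower number from compound 2 to compound 3 (0.38 log units; beyond the scatter) was only modest; none of them replaces the ring with a chain, so the data give no direct guide. The expected step is therefore a 1.1-fold higher number from compound 1 to compound 4 (0.05 log units; within the scatter), not beyond the scatter. Compound 4 is estimated at 11000 nM, between 3500 nM and 35000 nM.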

Compound 4, half-maximal inhibitory concentration: 160 nM
For compound 4 the middle estimate is 69-fold (1.84 log units) above the measured one, and the stated range ends above it.
By their numbers in this assay, from the lowest: compound 4; then compounds 3, 1 and 2 (each within the scatter of the next, the first and the last beyond it).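

Among the aromatic groups on this amide-type nitrogen, the largest change was a 2.4-fold lower number from compound 2 to compound 3 (0.38 log units; beyond the scatter). Replacing the ring with the 3-(dimethylamino)propyl chain goes much further, giving a 62-fold lower number from compound 1 to compound 4 (1.79 log units; beyond the scatter) and a 40-fold lower number from compound 3 to compound 4 (1.61 log units; beyond the scatter) and a 97-fold lower number from compound 2 to compound 4 (1.99 log units; beyond the scatter), so this position can move the number far more than the ring swaps suggested. Nothing available explains the gain. On these data alone, it remains open whether the ring's removal or the chain's dimethylamino group matters more, since a plain propyl chain would separate the two. As far as these compounds go, a longer chain or a carboxylic acid at the chain end also remains untested here.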